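The source may report more compounds than this note shows. Statements on the series, on what has been measured and on what is new or still open speak of the compounds shown alone.

Compound 1 `CCCCCC/C=C/C[C@H]1C[C@@H]([C@@H](O)c2ccccc2)CO[C@@H]1c1ccccc1`: 7400 nM
Compound 2 `O[C@@H](c1ccccc1)[C@H]1CO[C@H](c2ccccc2)[C@@H](C/C=C/c2cccc(F)c2)C1`: 8380 nM
Compound 3 `COc1ccc(/C=C/C[C@H]2C[C@@H]([C@@H](O)c3ccc(OC)c(OC)c3)CO[C@@H]2c2ccccc2)cc1OC`: 17000 nM

These numbers come from a functional assay on HeLa cells (Homo sapiens) for cytotoxicity, read by WST assay, with a stated time of 48 h; a higher number here means a weaker inhibitor, a lower number a stronger inhibitor. In this test, compound 2 at 8380 nM sits level with compound 1 within the scatter, while compound 3 at 17000 nM stands clearly higher than both.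

The next compound is compound 4 `Oc1ccc(/C=C/C[C@H]2C[C@@H]([C@@H](O)c3ccccc3)CO[C@@H]2c2ccccc2)cc1`. It keeps the core of compound 2 and changes one group: 4-hydroxyphenyl in place of 3-fluorophenyl on a double-bonded chain carbon bound to a double-bonded chain carbon. In words, 4-hydroxyphenyl comes in place of 3-fluorophenyl on a double-bonded chain carbon bound to a double-bonded chain carbon.

Within the data shown here, one measured step touches this same place: a 1.1-fold higher number from compound 1 to compound 2 (0.05 log units; within the scatter), with 3-fluorophenyl in place of hexyl. Even that swap of very different groups left the number within the scatter. Among the measured compounds shown here, no measured compound yet carries 4-hydroxyphenyl, so this evidence is thin.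

The expected change is a 1.1-fold higher number from compound 2 to compound 4 (0.03 log units; within the scatter), which means no real shift in either direction. The estimate for compound 4 is 9000 nM, with an expected range from 4000 nM to 20000 nM.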

Compound 4, half-maximal inhibitory concentration: 14400 nM
Compound 4: middle estimate off by 1.6-fold (0.20 log units), on the low side; the measured number falls inside the stated range.
By their numbers in this assay, from the lowest: compounds 1, 2, 4 and 3 (each within the scatter of the next, the first and the last beyond it).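

In this assay, swapping 3-fluorophenyl for 4-hydroxyphenyl on a double-bonded chain carbon bound to a double-bonded chain carbon stays within the scatter (a 1.7-fold higher number from compound 2 to compound 4 (0.24 log units; within the scatter)). The comparison with the hexyl compound also stays within the scatter (a 1.9-fold higher number from compound 1 to compound 4 (0.29 log units; within the scatter)), so hexyl, 3-fluorophenyl and 4-hydroxyphenyl cannot be told apart here, even though only 4-hydroxyphenyl carries a hydrogen-bond donor and a hydrogen-bond acceptor. Adding that donor and acceptor at this place therefore gives no shift that can be read with confidence, and nothing available explains the result.

As far as these compounds go, it remains open whether an amine, a carboxylic acid or a much longer chain at this place would move the number beyond the scatter. It is also unknown whether 4-methoxyphenyl would behave like 4-hydroxyphenyl.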